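Hydroxyphenyl for Difluorophenyl on the Diarylmethyl Arm

The source may report more compounds than this note shows. Statements on the series, on what has been measured and on what is new or still open speak of the compounds shown alone.

Measured compounds:
- Compound 1 `O=C(O)Cc1sc(C(c2ccc(F)cc2)c2ccc(F)cc2)nc1-c1cc(F)cc(F)c1`, which in an in vitro functional assay on HEK285-7 cells for antagonist activity at prostaglandin D2 receptor 2 (Homo sapiens), read by BRET and beta-arrestin recruitment (a higher number here means a larger maximal response, a lower number a smaller maximal response), gives 80%.
- Compound 2 `O=C(O)Cc1sc(C(c2ccc(F)cc2)c2ccc(F)cc2)nc1-c1ccnc(Cl)c1`, which in this assay gives 80%.
- Compound 3 `O=C(O)Cc1sc(C(c2ccccc2)c2ccc(F)c(F)c2)nc1-c1ccc(F)cc1`, which in this assay gives 80%.

Compound 3 stands level with compounds 1 and 2 at the digits shown; its values against both lie within the scatter, so no order among the three can be drawn. Among the measured compounds shown here, the one step with a single point of difference, no change at the digits printed from compound 1 to compound 2 (within the scatter), concerns an aromatic carbon on the other side of the shared core and shows no change beyond the scatter.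

Compound 4 `O=C(O)Cc1sc(C(c2ccccc2)c2ccc(O)cc2)nc1-c1ccc(F)cc1` is not yet measured. It differs from compound 3 in this way: 4-hydroxyphenyl in place of 3,4-difluorophenyl on a saturated chain carbon bound to two aromatic carbons

For the measured compounds named here, no measured step touches the saturated chain carbon bound to two aromatic carbons, so nothing here bears directly on the change. Going by the values given here, with the only step available, from compound 1 to compound 2, showing no movement, the expectation for compound 4 is a maximal response near that of compound 3, with the step of a number 2 percentage points lower from compound 3 to compound 4 (within the scatter) expected to stay within the scatter. Compound 4 is therefore estimated at 78%, between 60% and 92%.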

Compound 4, largest response reached (reported as efficacy), in percent of the reference or control that the assay uses: 80%
Estimate against measurement, compound 4: 2 percentage points below, and the stated range covers the measured number.
By their numbers in this assay, from the lowest: compounds 1, 2, 3 and 4 (each within the scatter of the next).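

In this assay the saturated chain carbon bound to two aromatic carbons now has a step of its own: 4-hydroxyphenyl in place of 3,4-difluorophenyl shows no change at the digits printed from compound 3 to compound 4 (within the scatter) and nothing more. The entering group carries a hydrogen-bond donor and a hydrogen-bond acceptor, the leaving group carries neither, and both fluorines go, yet this exchange leaves the maximal response as flat as the earlier step on the aromatic carbon did. Nothing at hand explains why the read-out stays put.

As far as these compounds go, whether an aminophenyl or methoxyphenyl group in place of 4-hydroxyphenyl on the same carbon would also leave the maximal response within the scatter remains open. So does the effect of exchanging the unsubstituted phenyl on that carbon for a cyclohexyl group.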